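The source may report more compounds than this note shows. Statements on the series, on what has been measured and on what is new or still open speak of the compounds shown alone.

Compound 1, whose structure is `CCCCCCCCCCCCn1cc(COC[C@@H]2OC[C@H](N)[C@@H]2O)nn1`, carries a long saturated chain on an aromatic nitrogen and a small sugar-like core bearing an amine and a hydroxyl group. In a functional assay on EC9706 cells (Homo sapiens) for antiproliferative activity, read by MTT assay, with a stated time of 48 h (on this read-out higher numbers stand for weaker inhibition and lower numbers for stronger inhibition), compound 1 gives 16000 nM. Compound 2, with structure `CCCCCCCCCCCCCCn1cc(COC[C@@H]2OC[C@H](N)[C@@H]2O)nn1`, differs from compound 1 only by the change (ethyl in place of hydrogen on a saturated chain carbon, ten or more bonds along the chain from an aromatic nitrogen), and in this assay compound 2 gives 7830 nM. That change produced a 2.0-fold lower number from compound 1 to compound 2 (0.31 log units; beyond the scatter).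

Compound 3, whose structure is `CCCCCCCCCCn1cc(COC[C@@H]2OC[C@H](N)[C@H]2O)nn1`, has a core that differs from the core of compound 1 in a way that is not broken down here; in this assay compound 3 gives 43100 nM, the highest number among the three measured compounds.

Compound 4, with structure `CCCCCCCCCCCCn1cc(COC[C@@H]2OC[C@H](N)[C@H]2O)nn1`, is made from compound 3 by the change (ethyl in place of hydrogen on a saturated chain carbon, ten or more bonds along the chain from an aromatic nitrogen), the same change that led from compound 1 to compound 2. For the measured compounds named here, for compound 4 the expected step is a 2.0-fold lower number from compound 3 to compound 4 (0.30 log units; within the scatter), because the earlier step of a 2.0-fold lower number from compound 1 to compound 2 (0.31 log units; beyond the scatter) gives the only measured example of this change. On that basis compound 4 is estimated at 21500 nM, expected to fall between 10000 nM and 45000 nM.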

Compound 4, half-maximal inhibitory concentration: 93800 nM
The estimate for compound 4 lay 4.4-fold (0.64 log units) below the measured number; measured number above the stated range.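

In this assay, the same ethyl change did not carry over from one core to the other, as it gave a 2.2-fold higher number from compound 3 to compound 4 (0.34 log units; beyond the scatter), the opposite direction to the earlier step: the same change on two cores in this assay, a 2.0-fold lower number (0.31 log units; beyond the scatter) from compound 1 to compound 2 and a 2.2-fold higher number (0.34 log units; beyond the scatter) from compound 3 to compound 4, 4.4-fold (0.65 log units) apart, beyond the scatter of two such steps. The two cores are closely related, and a single difference in drawn configuration goes with a 5.9-fold higher number from compound 1 to compound 4 (0.77 log units; beyond the scatter): the fact that compounds 1 and 4 differ only in the configuration as drawn. For the compounds shown here, with only one step on each core, this shows that the direction of the change depends on the core in these compounds, but it does not show why, or how the change would behave on any other core.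

The compounds shown leave open whether a longer chain on each core would extend these opposite trends or reverse them. They also leave open how either core would respond if a carboxylic acid replaced the amine.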